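The source may report more compounds than this note shows. Statements on the series, on what has been measured and on what is new or still open speak of the compounds shown alone.

Measured so far:
- compound 1 `N#Cc1ccc(N2CCc3cc(-c4cncnc4)ccc32)cc1C(F)(F)F`: "not determined" (no result reported)
- compound 2 `N#Cc1ccc(N2CCc3cc(-c4cnc5ccccc5c4)ccc3C2)cc1C(F)(F)F`: 25900 nM

For the measured compounds named here, in a functional assay on CWR22R cells (Homo sapiens) for antiproliferative activity, read by CCK-8 assay, with a stated time of 6 days (on this read-out higher numbers stand for weaker inhibition and lower numbers for stronger inhibition), compound 2 gives 25900 nM, the only number so far, so it cannot yet be ranked against any other compound. Compound 1 gives "not determined" (no result reported) and offers no comparison.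

The next compound is compound 3 `N#Cc1ccc(N2CCc3cc(-c4ccncc4)ccc3C2)cc1C(F)(F)F`, with pyridin-4-yl in place of quinolin-3-yl on an aromatic carbon. Going by the values given here, no step between measured compounds is available, so there is no precedent for this change, and the expectation rests only on compound 2 at 25900 nM and the change itself. No shift beyond the usual scatter is expected in this assay, and no firm direction can be given. The estimated step of a 1.3-fold lower number from compound 2 to compound 3 (0.11 log units; within the scatter) is correspondingly small. Compound 3 is expected at 20000 nM. The estimated range runs from 8000 nM to 50000 nM.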

Compound 3, half-maximal inhibitory concentration: 6940 nM
Estimate against measurement, compound 3: 2.9-fold (0.46 log units) above, and the stated range ends above it.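

In this assay the aromatic carbon carrying the quinolin-3-yl group of compound 2 accepts a smaller group without loss: pyridin-4-yl gives a 3.7-fold lower number from compound 2 to compound 3 (0.57 log units; beyond the scatter). The second, carbon-only aromatic ring of quinolin-3-yl is therefore not needed for activity at this position, and removing it, along with the change in where the ring nitrogen sits, goes with the lower number. No measured property of either group is at hand to account for the shift.

A single step cannot separate the loss of that ring from the new place of the ring nitrogen, and pyridin-3-yl or plain phenyl at this carbon would tell the two apart. Also open, as far as these compounds go, is how far this position tolerates non-aromatic groups, such as morpholine or a carboxylic acid.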